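The compounds below may be only part of what the source reports. "The series", "measured", "known", "first", "only" and "open" are said of these compounds alone.

Measured in a functional assay on MCF7 cells (Homo sapiens) for antiproliferative activity, read by MTT assay, with a stated time of 48 h; on this read-out higher numbers stand for weaker inhibition and lower numbers for stronger inhibition; each value is a limit of the assay:
- compound 1 `COc1cc(-c2cccc3nc(-c4ccccc4)oc23)cc(OC)c1OC` gives > 25000 nM
- compound 2 `COc1cc(-c2cccc3nc(-c4ccc(F)cc4)oc23)cc(OC)c1OC` gives > 25000 nM
- compound 3 `COc1cc(-c2cccc3nc(-c4cccc(Br)c4)oc23)cc(OC)c1OC` gives > 25000 nM

Compound 3 sits at the limit of > 25000 nM in this assay, at which 3 of the 3 values shown sit. Compound 4 `COc1cc(-c2cccc3nc(-c4ccc(Br)cc4)oc23)cc(OC)c1OC` is not yet measured. The change is 4-bromophenyl in place of 3-bromophenyl on an aromatic carbon; in words, 4-bromophenyl in place of 3-bromophenyl on an aromatic carbon. The measured steps that bear on it are a step that the two limits leave unreadable from compound 1 to compound 2 and a step that the two limits leave unreadable from compound 1 to compound 3 and a step that the two limits leave unreadable from compound 2 to compound 3. None of these gives a size, so no step beyond the scatter is expected in this assay, in either direction. The expected result is a number no higher from compound 3 to compound 4 (the limit leaves the size open). For compound 4 the estimate is 25000 nM, with an expected range from 12000 nM to 50000 nM, and a report as a limit is the likely outcome.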

Compound 4, half-maximal inhibitory concentration: > 25000 nM
Compound 4 gave a limit, no number; the forecaster's own chance of this, stated with the estimate: 85%; the middle value sits exactly at the limit.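

Compound 4, like compound 1, compound 2 and compound 3, is reported only as a limit in this assay, so no step among these compounds can be read: the limit of > 25000 nM in this assay, at which 4 of the 4 values shown sit.

The compounds shown leave open how far these four differ from one another in this assay, including whether 3-bromophenyl and 4-bromophenyl differ at all.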